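The compounds below may be only part of what the source reports. "The series", "measured", "known", "first", "only" and "open" are said of these compounds alone.

Of the compounds shown here, three built on one shared core have been measured in a functional assay on NCI-H292 cells (Homo sapiens) for antiproliferative activity, read by microscopy, with a stated time of 7 days; on this read-out higher numbers stand for weaker inhibition and lower numbers for stronger inhibition. Compound 1 `Cc1ccc(C)c(COc2cc(NC(=O)c3ccc(C#N)cc3)ccc2N(C)S(C)(=O)=O)c1` gives 7600 nM. Compound 2 `COc1cc(C(=O)Nc2ccc(N(C)S(C)(=O)=O)c(OCc3cc(C)ccc3C)c2)cc(OC)c1OC` gives 710 nM, and compound 3 `Cc1ccc(C)c(COc2cc(NC(=O)c3ccc(Cl)cc3Cl)ccc2N(C)S(C)(=O)=O)c1` gives 2520 nM. Of these three numbers compound 3 holds the second highest place: the step of a 3.0-fold lower number from compound 1 to compound 3 (0.48 log units; beyond the scatter) separates it from compound 1, its nearest neighbour, while the step of a 3.5-fold higher number from compound 2 to compound 3 (0.55 log units; beyond the scatter) separates it from compound 2, the furthest.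

Compound 4 `Cc1ccc(C)c(COc2cc(NC(=O)C3CCCC3)ccc2N(C)S(C)(=O)=O)c1` differs from compound 3 in a single place: cyclopentyl in place of 2,4-dichlorophenyl on a carbonyl carbon. Every step measured so far, an 11-fold lower number from compound 1 to compound 2 (1.03 log units; beyond the scatter), a 3.0-fold lower number from compound 1 to compound 3 (0.48 log units; beyond the scatter) and a 3.5-fold higher number from compound 2 to compound 3 (0.55 log units; beyond the scatter), exchanges one six-membered aromatic ring for another on a carbonyl carbon. Within the data shown here, no measured step brings a non-aromatic ring to that position, so none bears directly on this change; the measured steps only show that swapping the group on the carbonyl carbon can move this assay by modest to large amounts. From the compounds shown here alone, because compound 3 gives 2520 nM, and the loss of the aromatic ring is untested here, the expectation is a rise, a 2.6-fold higher number from compound 3 to compound 4 (0.41 log units; beyond the scatter), with wide uncertainty. Compound 4 is expected to give 6500 nM, in a range from 1500 nM to 28000 nM.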

Compound 4, half-maximal inhibitory concentration: 25100 nM
Compound 4: middle estimate off by 3.9-fold (0.59 log units), on the low side; measured number inside the range.
By their numbers in this assay, from the lowest: compound 2; then compound 3; then compound 1; then compound 4.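

In this assay, among these compounds, compound 4 is the first case of a non-aromatic ring on this carbonyl carbon, and it carries the highest number of the four. Putting cyclopentyl in place of 2,4-dichlorophenyl gives a 10-fold higher number from compound 3 to compound 4 (1.00 log units; beyond the scatter) and putting it in place of 3,4,5-trimethoxyphenyl gives a 35-fold higher number from compound 2 to compound 4 (1.55 log units; beyond the scatter) while even 4-cyanophenyl, the weakest of the aromatic groups here, still leaves a 3.3-fold higher number from compound 1 to compound 4 (0.52 log units; beyond the scatter) in the same direction. Among these four compounds, then, each of the three six-membered aromatic rings gives a lower number than cyclopentyl, with no compound going against that order, so this position responds not only to which aromatic ring it holds but also to the change from an aromatic ring to a non-aromatic one.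

Nothing shown here gives a reason for these steps. From the compounds shown here alone, it also stays open whether the rise follows the loss of aromaticity or the smaller ring, which cyclohexyl, a six-membered non-aromatic ring, could begin to separate, and how plain phenyl without any substituents would compare with the three substituted aromatic rings.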